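The source may report more compounds than this note shows. Statements on the series, on what has been measured and on what is new or still open speak of the compounds shown alone.

Compound 1 `C=C1[C@@H](OC(C)=O)C[C@@H]2[C@](C)(CO[Si](C)(C)C(C)(C)C)[C@H](OC(C)=O)CC[C@@]2(C)[C@@H]1C[C@@H](Nc1ccccc1)C1=CCOC1=O`: 4050 nM
Compound 2 `C=C1[C@@H](OC(C)=O)C[C@@H]2[C@](C)(COC=O)[C@H](OC(C)=O)CC[C@@]2(C)[C@@H]1C[C@@H](Nc1ccc(Br)cc1)C1=CCOC1=O`: 13200 nM
Compound 3 `C=C1[C@@H](OC(C)=O)C[C@@H]2[C@](C)(CO[Si](C)(C)C(C)(C)C)[C@H](OC(C)=O)CC[C@@]2(C)[C@@H]1C[C@@H](Nc1ccc(OC)cc1)C1=CCOC1=O`: 5370 nM

In a functional assay on HT-29 cells (Homo sapiens) for cytotoxicity, read by sulforhodamine B assay (a higher number here means a weaker inhibitor, a lower number a stronger inhibitor), compound 2 gives the highest of the three numbers, well beyond the scatter from both others. Compound 4 `C=C1[C@@H](OC(C)=O)C[C@@H]2[C@](C)(COC=O)[C@H](OC(C)=O)CC[C@@]2(C)[C@@H]1C[C@@H](Nc1cccc(F)c1)C1=CCOC1=O` is made from compound 2 by one change, (3-fluorophenyl in place of 4-bromophenyl on an amine nitrogen). Going by the values given here, only one measured step touches the amine-bound aryl group: a 1.3-fold higher number from compound 1 to compound 3 (0.12 log units; within the scatter). That pair differs elsewhere from compound 2 and compound 4, and the swap of a bromine for a fluorine is not mirrored anywhere, so the evidence is thin. Among the compounds with values here, since the one aryl change gave no step beyond the scatter, compound 4 is expected to stay close to compound 2, with the estimated step of a 1.3-fold lower number from compound 2 to compound 4 (0.12 log units; within the scatter). The estimate for compound 4 is 10000 nM, within 4500 nM to 25000 nM.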

Compound 4, half-maximal inhibitory concentration: 9410 nM
The estimate for compound 4 lay 1.1-fold (0.03 log units) above the measured number, within the range that was stated.
By their numbers in this assay, from the lowest: compounds 1, 3, 4 and 2 (each within the scatter of the next, the first and the last beyond it).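

In this assay, 3-fluorophenyl in place of 4-bromophenyl on the amine nitrogen gives a 1.4-fold lower number from compound 2 to compound 4 (0.15 log units; within the scatter), so on this version of the core, the aryl group can change both its halogen and that halogen's place without a shift beyond the scatter. No available measurement explains this result. The halogen and its place changed together, so their separate contributions cannot be told apart. Also open, from the compounds shown here alone, is whether a carboxylic acid or an amine on the ring, or a plain alkyl chain replacing the ring, would move the number further.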